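This account rests on a few compounds, and the source may have more. Where it says the series, first, only, none or still open, it means among the compounds named here.

Among the three compounds measured in a functional assay on HEK293 cells for agonist activity at D(4) dopamine receptor (Homo sapiens), read by FLIPR (on this read-out lower numbers stand for an effect already at smaller amounts and higher numbers for an effect only at larger amounts of compound), compound 3 `O=C(CN1CCC(c2cccc[n+]2[O-])CC1)Nc1cccc(Cl)c1` gives the lowest number, 62 nM. For comparison, compound 1 `CCc1cccc(NC(=O)CN2CCC(c3cccc[n+]3[O-])CC2)c1` gives 95 nM and compound 2 `O=C(CN1CCC(c2cccc[n+]2[O-])CC1)Nc1cccc(-c2ccccc2)c1` gives 360 nM; the step of a 1.5-fold lower number from compound 1 to compound 3 (0.19 log units; within the scatter) stays within the scatter, whereas a 5.8-fold lower number from compound 2 to compound 3 (0.76 log units; beyond the scatter) lies beyond it. Compound 4 `O=C(CN1CCC(c2cccc[n+]2[O-])CC1)Nc1cccc(C(F)(F)F)c1` differs from compound 3 only by trifluoromethyl in place of chloro on an aromatic carbon. The two earlier swaps at this same aromatic carbon bear on this step: exchanging ethyl for chloro, a 1.5-fold lower number from compound 1 to compound 3 (0.19 log units; within the scatter), stayed within the scatter, while the exchange from phenyl, a 5.8-fold lower number from compound 2 to compound 3 (0.76 log units; beyond the scatter), did not. Because the swap from ethyl to chloro gave a 1.5-fold lower number from compound 1 to compound 3 (0.19 log units; within the scatter) within the scatter, compound 4 is expected to show a step of a 1.5-fold higher number from compound 3 to compound 4 (0.16 log units; within the scatter), nothing beyond the scatter. The estimated value for compound 4 is 90 nM, ranging from 35 nM to 250 nM.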

Compound 4, half-maximal effective concentration: 76 nM
The estimate for compound 4 lay 1.2-fold (0.07 log units) above the measured number, within the range that was stated.
By their numbers in this assay, from the lowest: compounds 3, 4 and 1 (each within the scatter of the next); then compound 2.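

In this assay the step of a 1.2-fold higher number from compound 3 to compound 4 (0.09 log units; within the scatter) and the step of a 1.3-fold lower number from compound 1 to compound 4 (0.10 log units; within the scatter) both stay within the scatter, so at this aromatic carbon trifluoromethyl, with four heavy atoms, cannot be told apart from chloro, with one heavy atom, or from ethyl. Phenyl remains the only group here that stands apart, now against three groups rather than two, with a 4.7-fold lower number from compound 2 to compound 4 (0.68 log units; beyond the scatter) lying beyond the scatter. Nothing given here accounts for these steps. On these data alone, it remains open whether an amine or a carboxylic acid at this aromatic carbon would stay level with chloro, ethyl and trifluoromethyl or move as far as phenyl.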